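Three Limits and an Aminoethoxy Swap

The source may report more compounds than this note shows. Statements on the series, on what has been measured and on what is new or still open speak of the compounds shown alone.

Compound 1 `CCc1cc(F)ccc1-c1nc(-c2ccc3[nH]c(=O)oc3c2)cs1`: in an assay on isolated protein for inhibition of protein phosphatase 1D (Homo sapiens), read by malachite green (a higher number here means a weaker inhibitor, a lower number a stronger inhibitor), compound 1 gives < 20000 nM, which is a limit of the assay.
Compound 2 `COc1cc(F)ccc1-c1nc(-c2ccc3[nH]c(=O)oc3c2)cs1`: in this assay compound 2 gives < 20000 nM, also a limit.
Compound 3 `CN(C)Cc1cc(F)ccc1-c1nc(-c2ccc3[nH]c(=O)oc3c2)cs1`: in this assay compound 3 gives < 20000 nM, again a limit.

Compound 3 therefore stands at a limit, not at a number. The same holds for every value shown, as the limit of < 20000 nM in this assay, at which 3 of the 3 values shown sit, records, so no number separates the three compounds. For that reason the steps among them, a step that the two limits leave unreadable from compound 1 to compound 2, a step that the two limits leave unreadable from compound 1 to compound 3 and a step that the two limits leave unreadable from compound 2 to compound 3, cannot be read.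

Compound 4 `NCCOCc1cc(F)ccc1-c1nc(-c2ccc3[nH]c(=O)oc3c2)cs1` differs from compound 3 by 2-aminoethoxy in place of dimethylamino on a saturated chain carbon bound to an aromatic carbon. The three measured steps all change the same part of the shared core and so bear on this one, but each is unreadable, and none gives a size or a direction. Among the measured compounds shown here, no step in this assay beyond the scatter can thus be predicted from them; the most likely outcome is that compound 4 again sits at the limit. The estimate for compound 4 is 8000 nM, between 1500 nM and 20000 nM. That number means an expected step that the limit leaves unreadable from compound 3 to compound 4.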

Compound 4, half-maximal inhibitory concentration: < 20000 nM
Compound 4 ended at the assay's limit (the forecaster's own chance of this, stated with the estimate: 80%); the middle value lies beyond the limit too.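

The steps from compound 1, compound 2 and compound 3 to compound 4 cannot be read, because all four compounds sit at a single limit: the limit of < 20000 nM in this assay, at which 4 of the 4 values shown sit.

The compounds shown leave open how strongly each one inhibits the enzyme, and whether any of these changes to the shared core alters that strength.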